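The source may hold more compounds than are shown below. What is called first, only, known or untested is meant among the compounds shown, and "the series" means these compounds.

Working notes on the spirocyclic amide series, antagonism at the orexin type 1 receptor.

Three compounds carry numbers in a functional assay on CHO cells for antagonist activity at Orexin/Hypocretin receptor type 1 (Homo sapiens), read by FLIPR and calcium flux; on this read-out higher numbers stand for higher potency (the scale is a negative logarithm) and lower numbers for lower potency. Compound 1 `O=C(c1nc(C(F)(F)F)ccc1-c1ncccn1)N1CC2(CC2)C[C@H]1CNc1ccc(C(F)(F)F)cn1` gives 6.7 in this assay. Compound 3 `Cc1nc(C(=O)N2CCC3(CC3)C[C@H]2CNc2ccc(Cl)cn2)c(-c2ccccc2)s1` gives 7.9 in this assay. Compound 2 `Cc1ccnc(NC[C@@H]2CC3(CC3)CN2C(=O)c2nc(C)sc2-c2ccccc2)n1` gives 6.1 in this assay and stands lowest of the three: compound 1 is nearest, with a number higher by a margin beyond the scatter, and compound 3 is furthest, higher by a margin also beyond the scatter. Within the data shown here, none of these pairs differs in a single place, so no step is attributed to one change.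

Compound 4 `Cc1nc(C(=O)N2CC3(CC3)C[C@H]2CNc2ccc(C(F)(F)F)cn2)c(-c2ccccc2)s1` shares the core of compound 2 and differs from it at one site: 5-(trifluoromethyl)pyridin-2-yl in place of 4-methylpyrimidin-2-yl on an amine nitrogen. The same five-membered aromatic core and spirocycle are kept; only the aryl group on the amine nitrogen changes. Among the measured compounds shown here, no measured pair isolates this exchange, so the expectation rests on where compound 2 stands relative to the other two, which both sit higher in this assay.

The step from compound 2 to compound 4 is expected to be an increase of a number 0.90 log units higher from compound 2 to compound 4 (beyond the scatter) in this assay, modest and possibly beyond the scatter. Compound 4 is estimated at 7 in this assay, in the range 6.4 to 7.7.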

Compound 4, negative logarithm of the antagonist equilibrium constant: 8.4
For compound 4 the middle estimate is 1.40 log units below the measured one, and the stated range ends below it.
By their numbers in this assay, from the lowest: compound 2; then compound 1; then compound 3; then compound 4.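

Among these compounds, the exchange of 4-methylpyrimidin-2-yl for 5-(trifluoromethyl)pyridin-2-yl on the amine nitrogen is the first change that can be read on its own, and in this assay it gives a large step, a number 2.30 log units higher from compound 2 to compound 4 (beyond the scatter). Among the compounds shown here, with the rest of the structure held constant, the aryl group on this amine nitrogen is therefore a position at which potency on this read-out can move strongly, a point the earlier compounds, none of which formed a single-site pair, could not show. The aromatic ring and its substituent change together in this exchange, so the step belongs to the whole group, and nothing at hand bears on the reason for its size.

The compounds shown do not separate the contribution of the ring from that of the substituent, a question that a pair such as 5-(trifluoromethyl)pyrimidin-2-yl and 5-methylpyridin-2-yl on the same amine nitrogen would address. From the compounds shown here alone, it also remains open whether a nitrile in place of the trifluoromethyl would hold the gain, and whether the same exchange gives a step of similar size on the other amide portions of the series.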